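Swapping Nitro for Amino in Compound 3

A few compounds are considered here, and "the series" means these few. Any claim that something is new, unique, unknown or untested is made for them only; others in the source may bear on it.

In a functional assay on K562 cells (Homo sapiens) for cytotoxicity, read by trypan blue exclusion, with a stated time of 96 h (on this read-out higher numbers stand for weaker inhibition and lower numbers for stronger inhibition), compound 1 (`COc1ccccc1/C=C/S(=O)(=O)Cc1ccc(OC)c([N+](=O)[O-])c1`) gives 20000 nM, compound 2 (`COc1ccc(CS(=O)(=O)/C=C/c2ccccc2OC)cc1N`) gives 7500 nM and compound 3 (`COc1ccc(CS(=O)(=O)/C=C/c2c(OC)cccc2OC)cc1[N+](=O)[O-]`) gives 20000 nM. Compound 3 therefore stands level with compound 1, and both numbers lie above that of compound 2. Compound 4 (`COc1ccc(CS(=O)(=O)/C=C/c2c(OC)cccc2OC)cc1N`) differs from compound 3 by a single change, amino in place of nitro on an aromatic carbon, ortho to a methoxy group: amino in place of nitro on an aromatic carbon. Going by the values given here, two measured steps bear on it. The same swap gave a 2.7-fold lower number from compound 1 to compound 2 (0.43 log units; beyond the scatter), a modest step. The added methoxy gave no change at the digits printed from compound 1 to compound 3 (within the scatter), so compound 3 offers a starting number no different from that of compound 1. The swap has been measured only once, and only without the added methoxy, so its size here remains uncertain. A modest step toward a lower number is expected, estimated as a 2.7-fold lower number from compound 3 to compound 4 (0.43 log units; beyond the scatter). Compound 4 is estimated at 7500 nM, with an expected range of 2500 nM to 20000 nM.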

Compound 4, half-maximal inhibitory concentration: 50 nM
Compound 4: middle estimate off by 150-fold (2.18 log units), on the high side; measured number outside the range, below it.
By their numbers in this assay, from the lowest: compound 4; then compound 2; then compounds 1 and 3 (each within the scatter of the next).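

In this assay the swap of amino for nitro has no fixed size, as it now gives a 400-fold lower number from compound 3 to compound 4 (2.60 log units; beyond the scatter), far more than on the core without the added methoxy: the same change on two cores in this assay, a 2.7-fold lower number (0.43 log units; beyond the scatter) from compound 1 to compound 2 and a 400-fold lower number (2.60 log units; beyond the scatter) from compound 3 to compound 4, 150-fold (2.18 log units) apart, beyond the scatter of two such steps

The added methoxy also depends on its partner, doing nothing measurable with nitro present yet giving a 150-fold lower number from compound 2 to compound 4 (2.18 log units; beyond the scatter) with amino present: the same change on two cores in this assay, no change at the digits printed (within the scatter) from compound 1 to compound 3 and a 150-fold lower number (2.18 log units; beyond the scatter) from compound 2 to compound 4, 150-fold (2.18 log units) apart, beyond the scatter of two such steps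

The two changes therefore do not add up independently across these four compounds, and the large drop appears only when amino and the added methoxy occur together, in compound 4.

The compounds shown leave open whether an acetamide or a hydroxyl group could take the place of the amino group and keep so low a number. They also leave open whether an ethoxy group or a fluorine atom could stand in for the added methoxy.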